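Swapping a lactam ring for an anilino group

The compounds below may be only part of what the source reports. "The series", "measured", "known", "first", "only" and "open" are said of these compounds alone.

Compound 1 `O=C1CCCN1c1cnc(NCc2c(F)ccc3c2CCO3)n2cnnc12` carries a 2-oxopyrrolidin-1-yl group on its shared core. In an ADME assay on microsomes from liver (Homo sapiens) for metabolic stability, read by LC-MS, using NADPH, with stated times of 5 min and 30 min, tested at 1 uM (a lower number here means slower removal, a higher number faster removal of the compound), compound 1 gives < 3 mL.min-1.g-1, which is a limit of the assay rather than a number, so its true clearance is known only to sit at the limit of < 3 mL.min-1.g-1 in this assay, at which 1 of the 2 values shown sits. Compound 2 `CN(C)Cc1ccc2c(c1)CN(c1cnc(NCc3c(F)ccc4c3CCO4)c3cn[nH]c(=O)c13)C2=O`, built differently in several places, gives 32 mL.min-1.g-1 in this assay. Compound 3 `Fc1ccc2c(c1CNc1ncc(Nc3ccccc3)c3nncn13)CCO2` differs from compound 1 by anilino in place of 2-oxopyrrolidin-1-yl on an aromatic carbon. For the measured compounds named here, with no measured step of this kind to lean on, the expected change from compound 1 is a rise beyond the scatter, an at least 3.3-fold higher number from compound 1 to compound 3 (0.52 log units; beyond the scatter), so compound 3 is estimated at 10 mL.min-1.g-1, between 3 mL.min-1.g-1 and 30 mL.min-1.g-1.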

Compound 3, intrinsic clearance in microsomes: 20 mL.min-1.g-1
For compound 3 the middle estimate is 2.0-fold (0.30 log units) below the measured one; the range from low to high includes it.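

In this assay, for the compounds shown here, this aromatic carbon proves sensitive to the group it carries: anilino in place of 2-oxopyrrolidin-1-yl gives an at least 6.6-fold higher number from compound 1 to compound 3 (0.82 log units; beyond the scatter) and is the first change here made in one place alone. Compound 2 differs from compound 1 in several places, so it could not show this. On these data alone, the value of compound 1 is a limit, so the full size of the step stays unknown: the limit of < 3 mL.min-1.g-1 in this assay, at which 1 of the 3 values shown sits.

Still open, as far as these compounds go, is whether a saturated amine such as morpholine, or an open-chain amide such as acetamido, would stay near compound 1 or move toward compound 3.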